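The source may report more compounds than this note shows. Statements on the series, on what has been measured and on what is new or still open speak of the compounds shown alone.

In a functional assay on MCF7 cells (Homo sapiens) for cytotoxicity, read by MTT assay, with a stated time of 48 h (a lower number here means a stronger inhibitor, a higher number a weaker inhibitor), compound 1, whose structure is `COc1ccc(-n2nnnc2C(Nc2ccc([Se][Se]c3ccc(NC(c4nnnn4-c4ccc(OC)cc4)C(C)C)cc3)cc2)C(C)C)cc1`, gives a reading that is a limit of the assay rather than a number, >= 100000 nM. Among the compounds with values here, compound 2, with the structure `CC1=C([Se]c2ccc(NCc3nnnn3C(C)(C)C)cc2)C(=O)c2ccccc2C1=O`, is the one compound here with a measured number: in this assay compound 2 gives 42000 nM. Within the data shown here, compound 2 therefore stands as the only numerical value shown, the other reading being a limit; on this point the limit of >= 100000 nM in this assay, at which 1 of the 2 values shown sits, sets the bounds of what is known.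

Compound 3, `CC1=C([Se]c2ccc(NC(c3ccc(C)cc3)c3nnnn3C(C)(C)C)cc2)C(=O)c2ccccc2C1=O`, differs from compound 2 in one place: 4-methylphenyl in place of hydrogen on a saturated chain carbon bound to an aromatic carbon and a nitrogen on an aromatic ring. Among the measured compounds shown here, no measured pair in this set follows such a change, so there is no step to lean on. Without such a step the expectation is for no movement beyond the usual scatter in this assay, in either direction. The step from compound 2 to compound 3 is accordingly estimated as a 1.3-fold lower number from compound 2 to compound 3 (0.12 log units; within the scatter). For compound 3 the value expected in this assay is 32000 nM, with a range from 8000 nM to 120000 nM.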

Compound 3, half-maximal inhibitory concentration: >= 100000 nM
Compound 3: a limit, no number (the forecaster's own chance of this, stated with the estimate: 15%); middle value at least 3.1-fold (0.49 log units) away from the limit.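

In this assay compound 3 gives >= 100000 nM, which is a limit of the assay and not a number. Within the data shown here, putting 4-methylphenyl in place of hydrogen on a saturated chain carbon bound to an aromatic carbon and a nitrogen on an aromatic ring gives an at least 2.3-fold higher number from compound 2 to compound 3 (0.37 log units; beyond the scatter), so this position, for which the earlier compounds offered no step, does respond to substitution, and the response is towards a weaker inhibitor. The step is bounded on one side only, and its true size remains unknown: the limit of >= 100000 nM in this assay, at which 2 of the 3 values shown sit.

The compounds shown leave open whether methyl, an unsubstituted phenyl or a phenyl bearing a carboxylic acid at this same carbon would also raise the number, or whether any group there would keep the reading close to that of compound 2. Among these compounds, this is also the only pair carrying the change, so whether 4-methylphenyl would act in the same way on the core of compound 1 stays open.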